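Adding Bromine to the Sulfanyl Ring of Compound 1

The source may hold more compounds than are shown below. What is called first, only, known or untested is meant among the compounds shown, and "the series" means these compounds.

Compound 1 `CC(O)(CSc1ccccc1)c1nc(-c2ccc(F)c(Cl)c2)no1` was tested in a functional assay on DU-145 cells (Homo sapiens) for cytotoxicity, read by MTT assay (a higher number here means a weaker inhibitor, a lower number a stronger inhibitor), where compound 1 gives 5500 nM. Of the two numbers recorded so far this is the higher one, but only narrowly. Compound 2 `CC(O)(CSc1ccccc1)c1nc(-c2ccc(Cl)cc2)no1`, which carries a 4-chlorophenyl group in place of the 3-chloro-4-fluorophenyl group, gives 4500 nM, and the step between them, a 1.2-fold lower number from compound 1 to compound 2 (0.09 log units; within the scatter), lies within the scatter of repeated measurements, so the two compounds cannot be told apart on these data.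

Compound 3 `CC(O)(CSc1ccc(Br)cc1)c1nc(-c2ccc(F)c(Cl)c2)no1` differs from compound 1 in one place: bromo in place of hydrogen on an aromatic carbon, on the ring attached through sulfur, para to a large group. Among the measured compounds shown here, the single measured step concerns the other aromatic ring and does not touch the phenylsulfanyl ring, so no measured step bears directly on this change. Without such evidence, the expected step is a 1.4-fold lower number from compound 1 to compound 3 (0.14 log units; within the scatter), which stays within the scatter. Compound 3 is therefore estimated at 4000 nM in this assay, with a plausible range from 1500 nM to 11000 nM.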

Compound 3, half-maximal inhibitory concentration: 8800 nM
The estimate for compound 3 lay 2.2-fold (0.34 log units) below the measured number, and the stated range covers the measured number.
By their numbers in this assay, from the lowest: compounds 2, 1 and 3 (each within the scatter of the next).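

The bromo group is the first change shown on the ring attached through sulfur, since the earlier step between compound 1 and compound 2 concerned only the other aromatic ring. In this assay, going from phenyl to 4-bromophenyl gives a 1.6-fold higher number from compound 1 to compound 3 (0.20 log units; within the scatter), so this pair cannot be told apart, and a single bromine atom at this place, para to a large group, leaves the cytotoxicity reading within the noise of the measurement, at least on the core of compound 1. No separate measurement is available to help interpret this result.

Still open, as far as these compounds go, is whether a different kind of group at this same place, such as an amine, a carboxylic acid or a longer chain, would shift the number by more than the scatter, which would show whether this position matters for the reading at all. Also open, from the compounds shown here alone, is whether bromo on this ring would give a similar result when paired with the 4-chlorophenyl group of compound 2, rather than with the 3-chloro-4-fluorophenyl group of compound 1.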